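The source may report more compounds than this note shows. Statements on the series, on what has been measured and on what is new or still open speak of the compounds shown alone.

Working notes on the series. The shared core is carried by compound 1 `O=C1NC(=O)C(Cc2ccc(Oc3ccc(C(F)(F)F)cn3)cc2)S1`, by compound 2 `Cc1cc(Oc2ccc(CC3SC(=O)NC3=O)cc2)nc(C(F)(F)F)c1` and by compound 3 `O=C1NC(=O)C(Cc2ccc(Oc3ncc(C(F)(F)F)cc3Cl)cc2)S1`. In a functional assay for agonist activity at Free fatty acid receptor 1 (Homo sapiens), read by FLIPR, in the presence of a further agent that is not named here (on this read-out higher numbers stand for an effect only at larger amounts of compound and lower numbers for an effect already at smaller amounts), compound 1 gives 558 nM, compound 2 gives 688 nM and compound 3 gives 69 nM. Among these three numbers compound 1 stands second highest: compound 2 is the nearest, and the two values lie within the scatter of each other; compound 3 is the furthest, and the only single-point step so far is an 8.1-fold lower number from compound 1 to compound 3 (0.91 log units; beyond the scatter).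

Compound 4 `O=C1NC(=O)C(Cc2ccc(Oc3ccc(Cl)cn3)cc2)S1` is the next point on this line. Relative to compound 1 it carries chloro in place of trifluoromethyl on an aromatic carbon. Within the data shown here, no measured step exchanges trifluoromethyl for chloro anywhere; the one step that is known concerns a chloro entering at a different position and in place of hydrogen, so it does not speak directly to this change. With nothing that bears on it, the expectation in this assay is a step of about a 1.2-fold higher number from compound 1 to compound 4 (0.07 log units; within the scatter), that is, no change beyond the scatter in either direction. Compound 4 is therefore estimated at 650 nM, with a range from 220 nM to 1900 nM.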

Compound 4, half-maximal effective concentration: 1870 nM
For compound 4 the middle estimate is 2.9-fold (0.46 log units) below the measured one; the measured number falls inside the stated range.
By their numbers in this assay, from the lowest: compound 3; then compounds 1 and 2 (each within the scatter of the next); then compound 4.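

In this assay, among these compounds, the position two atoms from the ring nitrogen and para to a large group proves sensitive to its substituent: chloro in place of trifluoromethyl gives a 3.4-fold higher number from compound 1 to compound 4 (0.53 log units; beyond the scatter), the first measured change at this position. Chloro now appears on both sides, since the earlier step in which it replaces hydrogen at a different position is an 8.1-fold lower number from compound 1 to compound 3 (0.91 log units; beyond the scatter), so its direction here depends on where it sits and what it replaces. No measurement on hand accounts for this step.

With only trifluoromethyl and chloro shown at this position, the loss of one cannot be separated from the entry of the other. Going by these compounds, how a hydrogen, a methyl, a methoxy or a nitrile would stand here remains open, as does the effect of this exchange in the presence of the chloro of compound 3.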